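Cyclopropyl Gives Way to 4-Methoxyphenyl on a Shared Core

A few compounds are considered here, and "the series" means these few. Any claim that something is new, unique, unknown or untested is made for them only; others in the source may bear on it.

Three related compounds have been measured in a functional assay on HCT-116 cells (Homo sapiens) for cytotoxicity, read by MTT assay, with a stated time of 48 h, in the presence of a further agent that is not named here (a lower number here means that less compound is needed, a higher number that more compound is needed for the effect), so far. Compound 1 `Cc1c(Cc2ccccc2)c(NNC(=O)Nc2cc(Cl)nc(Cl)c2)nc2c1cnn2C` gives 13600 nM in this test, and compound 2 `COc1cc(NC(=O)NNc2cc(-c3ccccc3)c3cnn(C)c3n2)cc(Cl)n1` gives 31300 nM in the same test. Compound 3 `Cc1nn(C)c2nc(NNC(=O)Nc3cc(Cl)nc(Cl)c3)cc(C3CC3)c12` gives 67700 nM here, the highest of the three numbers, so more of it is needed for the effect than of either other compound. Its nearest neighbour on this scale is compound 2, and compound 1 lies furthest away.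

Compound 4 `COc1ccc(-c2cc(NNC(=O)Nc3cc(Cl)nc(Cl)c3)nc3c2c(C)nn3C)cc1` has not yet been measured. It has 4-methoxyphenyl in place of cyclopropyl on an aromatic carbon of compound 3 4-methoxyphenyl in place of cyclopropyl on an aromatic carbon and is otherwise unchanged.

For the measured compounds named here, no two measured compounds differ in only one place, so the expectation rests on indirect evidence. Compound 2 also carries an aromatic ring of carbon only in place of the cyclopropyl and gives 31300 nM, although it differs from compound 3 elsewhere too. A move towards a lower number therefore seems likely. The estimated change is a 2.5-fold lower number from compound 3 to compound 4 (0.40 log units; beyond the scatter), modestly beyond the usual scatter. For compound 4 the estimated value is 27000 nM, with an expected range from 10000 nM to 70000 nM.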

Compound 4, half-maximal effective concentration: 82300 nM
The estimate for compound 4 lay 3.0-fold (0.48 log units) below the measured number; measured number above the stated range.
By their numbers in this assay, from the lowest: compound 1; then compound 2; then compounds 3 and 4 (each within the scatter of the next).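

In this assay, putting 4-methoxyphenyl in place of cyclopropyl on this aromatic carbon gives a 1.2-fold higher number from compound 3 to compound 4 (0.08 log units; within the scatter), so the two compounds cannot be told apart in this test. For the compounds shown here, this is the first step that changes only one place, and it lets this position be read directly rather than through compounds that also differ elsewhere. Here, a three-membered non-aromatic ring with 3 heavy atoms gives way to a six-membered aromatic ring carrying a methoxy group, with 8 heavy atoms and one hydrogen-bond acceptor, yet the number stays within the usual scatter, and no measurement shown offers an explanation for this.

Going by these compounds, whether a much different group at this position, such as an amine or a carboxylic acid, would move the number beyond the scatter remains open. Also open, on these data alone, is whether the same exchange would leave the number as little altered if made on a compound that differs elsewhere on the shared core.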